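The compounds below may be only part of what the source reports. "The series", "measured", "known", "first", "only" and "open" are said of these compounds alone.

From the compounds shown here alone, in a functional assay on B16-F10 cells (Mus musculus) for antiproliferative activity, read by ELISA and MTT assay, with a stated time of 48 h (a lower number here means a stronger inhibitor, a higher number a weaker inhibitor), three compounds have been measured so far and a fourth is still open. Compound 1 `O=C(/C=C/c1ccc(F)cc1)NS(=O)(=O)c1ccc(Br)cc1` gives 2.8 ug/mL in this assay. Compound 2 `O=C(/C=C/c1ccc(Cl)cc1)NS(=O)(=O)c1ccc(Br)cc1` gives 2.8 ug/mL in this assay. The structural change between them is chloro in place of fluoro on an aromatic carbon, and the step it made was no change at the digits printed from compound 1 to compound 2 (within the scatter). Compound 3 `O=C(/C=C/c1ccc(Br)cc1)NS(=O)(=O)c1ccc(F)cc1` is built from the same atoms as compound 1, joined differently, and in this assay compound 3 gives 1.2 ug/mL. The difference between the two cores is not broken down here. Compound 3 stands lowest of the three numbers, and both compound 1 and compound 2 sit beyond the scatter from it, so compound 3 is the strongest inhibitor among the measured compounds.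

Compound 4 `O=C(/C=C/c1ccc(Br)cc1)NS(=O)(=O)c1ccc(Cl)cc1` has not yet been measured. It differs from compound 3 by chloro in place of fluoro on an aromatic carbon, the same change, at the same place, that separates compound 1 from compound 2. The expectation for compound 4 rests on the earlier step of no change at the digits printed from compound 1 to compound 2 (within the scatter), which this change made once already. On that basis the step from compound 3 to compound 4 is expected to be a 1.2-fold higher number from compound 3 to compound 4 (0.07 log units; within the scatter). Compound 4 is therefore estimated to give about 1.4 ug/mL in this assay, with a likely range from 0.6 ug/mL to 3 ug/mL.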

Compound 4, half-maximal inhibitory concentration: 5.2 ug/mL
Compound 4: the middle estimate sits 3.7-fold (0.57 log units) below what was measured; the whole stated range lies below it.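

On the core of compound 3, chloro in place of fluoro on an aromatic carbon gave a 4.3-fold higher number from compound 3 to compound 4 (0.64 log units; beyond the scatter) in this assay, so in this pair the swap weakened inhibition. Among the compounds shown here, the same swap therefore did not carry over from one core to the other with the same size of step: the same change on two cores in this assay, no change at the digits printed (within the scatter) from compound 1 to compound 2 and a 4.3-fold higher number (0.64 log units; beyond the scatter) from compound 3 to compound 4, 4.3-fold (0.64 log units) apart, beyond the scatter of two such steps What this does not show is why the two cores respond differently, and with a single pair on each core it gives no general rule for how this change behaves across the series; it shows only that the step seen on the core of compound 1 could not be relied on for the core of compound 3.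

The compounds shown leave open how other groups in the same place would behave on each core, for example a methoxy group, a nitrile or an amine in place of the halogen. They also leave open whether the difference between the two cores would persist with bromo replaced by a group such as methyl or a carboxylic acid.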